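Amide series: the step from compound 3 to compound 4

The source may report more compounds than this note shows. Statements on the series, on what has been measured and on what is new or still open speak of the compounds shown alone.

Measured so far in an ADME assay on HepG2 2.2.15 cells (Homo sapiens) for cytotoxicity, read by CCK-8 assay, with a stated time of 8 days (on this read-out lower numbers stand for higher toxicity in this test and higher numbers for lower toxicity in this test), for these compounds:
compound 1 `CCOc1ccc(-c2cc(NC(=O)c3ccccc3O)c[nH]c2=O)cc1` gives 41000 nM
compound 2 `CCOc1ccc(-c2cc(NC(=O)c3cc(OC)ccc3O)c[nH]c2=O)cc1` gives 57700 nM
compound 3 `CCOc1ccc(-c2cc(NC(=O)c3ccc(Cl)cc3O)c[nH]c2=O)cc1` gives 28600 nM

Compound 3 stands within the scatter of the other two, with gaps of a 1.4-fold lower number from compound 1 to compound 3 (0.16 log units; within the scatter) and a 2.0-fold lower number from compound 2 to compound 3 (0.30 log units; within the scatter) on the shared core. The change to compound 4 `CCOc1ccc(-c2cc(NC(=O)c3cccc(OC)c3O)c[nH]c2=O)cc1` is 2-hydroxy-3-methoxyphenyl in place of 4-chloro-2-hydroxyphenyl on a carbonyl carbon and leaves that core untouched. The closest measured change, methoxy in place of hydrogen, gave a 1.4-fold higher number from compound 1 to compound 2 (0.15 log units; within the scatter) and also stays within the scatter. No step beyond the scatter is therefore expected in this assay for this change. The estimated move is a 1.6-fold higher number from compound 3 to compound 4 (0.20 log units; within the scatter) and remains within the scatter. For compound 4 the expected value is 45000 nM (estimated range 24000 nM to 85000 nM).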

Compound 4, half-maximal cytotoxic concentration: 34500 nM
Estimate against measurement, compound 4: 1.3-fold (0.12 log units) above, and the stated range covers the measured number.
By their numbers in this assay, from the lowest: compounds 3, 4, 1 and 2 (each within the scatter of the next).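

In this assay the 2-hydroxy-3-methoxyphenyl amide shows no step beyond the scatter against any of the three earlier amides (a 1.2-fold higher number from compound 3 to compound 4 (0.08 log units; within the scatter); a 1.7-fold lower number from compound 2 to compound 4 (0.22 log units; within the scatter); a 1.2-fold lower number from compound 1 to compound 4 (0.07 log units; within the scatter)). Methoxy in place of hydrogen on an aromatic carbon has now given a step within the scatter in two placements, as 2-hydroxy-5-methoxyphenyl and as 2-hydroxy-3-methoxyphenyl. No measurement explains why these values stay together.

Still open, from the compounds shown here alone, is whether an amine or a carboxylic acid on this aromatic ring would give a step beyond the scatter. Going by these compounds, all four compounds also keep the hydroxy group, so its replacement remains untested here.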